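Chain-extended flavone ethers with piperidine amines: a weak series

The compounds below may be only part of what the source reports. "The series", "measured", "known", "first", "only" and "open" are said of these compounds alone.

Compound 1 `COc1ccc(-c2cc(=O)c3ccc(OCCCN4CCC(CCO)CC4)cc3o2)cc1` carries a 4-(2-hydroxyethyl)piperidin-1-yl group three bonds along the chain from the aromatic oxygen. In a functional assay for inhibition, read by fluorescence and spectrophotometry, with a stated time of 30 h (a lower number here means a stronger inhibitor, a higher number a weaker inhibitor), compound 1 gives 43200 nM. Compound 2 `COc1ccc(-c2cc(=O)c3ccc(OCCCCN4CCC(C)CC4)cc3o2)cc1` differs by (4-methylpiperidin-1-yl)methyl in place of 4-(2-hydroxyethyl)piperidin-1-yl on a saturated chain carbon, three bonds along the chain from an oxygen on an aromatic ring, and this change produced a 1.1-fold higher number from compound 1 to compound 2 (0.05 log units; within the scatter). Compound 3 `COc1ccc(-c2cc(=O)c3ccc(OCCCCCN4CCC(CCO)CC4)cc3o2)cc1` has a longer chain; its core differs from that of compound 1 by a group of 11 heavy atoms (9 carbon, 1 nitrogen, 1 oxygen; one six-membered non-aromatic ring with 1 hetero atom) in place of a group of 9 heavy atoms (7 carbon, 1 nitrogen, 1 oxygen; one six-membered non-aromatic ring with 1 hetero atom), on a saturated chain carbon, three bonds along the chain from an oxygen on an aromatic ring. In this assay compound 3 gives 49400 nM and compound 2 gives 48200 nM; all three numbers lie within the scatter of one another.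

Compound 4 `COc1ccc(-c2cc(=O)c3ccc(OCCCCCCN4CCC(C)CC4)cc3o2)cc1` is not yet measured. It differs from compound 3 by (4-methylpiperidin-1-yl)methyl in place of 4-(2-hydroxyethyl)piperidin-1-yl on a saturated chain carbon, five bonds along the chain from an oxygen on an aromatic ring. This is the same kind of change as that from compound 1 to compound 2, not the same change: there the place is three bonds along the chain from the aromatic oxygen, here it is five. Because the earlier step was a 1.1-fold higher number from compound 1 to compound 2 (0.05 log units; within the scatter), the step from compound 3 to compound 4 is expected to be similarly small, about a 1.1-fold higher number from compound 3 to compound 4 (0.02 log units; within the scatter). Compound 4 is therefore estimated at 52000 nM, with a likely range from 26000 nM to 104000 nM.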

Compound 4, half-maximal inhibitory concentration: 57200 nM
Beside the measured number, compound 4's estimate is 1.1-fold (0.04 log units) below it, within the range that was stated.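

Set on two cores in this assay, the same change, (4-methylpiperidin-1-yl)methyl in place of 4-(2-hydroxyethyl)piperidin-1-yl, gave matching results, with a 1.2-fold higher number from compound 3 to compound 4 (0.06 log units; within the scatter) on the longer chain: the same change on two cores in this assay, a 1.1-fold higher number (0.05 log units; within the scatter) from compound 1 to compound 2 and a 1.2-fold higher number (0.06 log units; within the scatter) from compound 3 to compound 4, 1.0-fold (0.02 log units) apart, within the scatter of two such steps. Going by these compounds alone, the other two new steps, a 1.2-fold higher number from compound 2 to compound 4 (0.07 log units; within the scatter) and a 1.3-fold higher number from compound 1 to compound 4 (0.12 log units; within the scatter), are also small, and no step among the four compounds lies beyond the scatter. This shows that the change carried from one of these two cores to the other without a detectable difference, but it does not show that the change has any real effect on either core, nor that it would behave the same way on a core giving a much lower number.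

The compounds shown leave open whether a shorter chain, or a morpholine or piperazine in place of the piperidine, would move the number beyond the scatter. They also leave open what a carboxylic acid on the piperidine would do in this assay.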